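The compounds below may be only part of what the source reports. "The series", "measured", "known", "first", "only" and "open" are said of these compounds alone.

Measured compounds:
Compound 1, `O=C(N[C@H]1CC[C@H](C(=O)O)CC1)[C@H](C1CCCCC1)n1c(-c2ccc(Cl)nc2)nc2cc(F)c(F)cc21`, gives 9700 nM in a functional assay for agonist activity at Bile acid receptor (Homo sapiens), read by a luciferase reporter; on this read-out higher numbers stand for an effect only at larger amounts of compound and lower numbers for an effect already at smaller amounts.
Compound 2, `O=C(O)Cc1ccc(NC(=O)C(C2CCCCC2)n2c(-c3ccc(Cl)cc3)nc3cc(F)c(F)cc32)cc1`, gives 4900 nM in this assay.
Compound 3, `O=C(O)CCc1ccc(NC(=O)[C@H](C2CCCCC2)n2c(-c3ccc(Cl)cc3)nc3cc(F)c(F)cc32)c(F)c1`, gives 36 nM in this assay.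

Among these three numbers compound 2 has the second highest. Its nearest neighbour is compound 1, whose number lies within the usual scatter of compound 2, so the two cannot be told apart. The furthest is compound 3, whose number lies far below, beyond the scatter.

Compound 4, `O=C(O)c1ccc(NC(=O)C(C2CCCCC2)n2c(-c3ccc(Cl)cc3)nc3cc(F)c(F)cc32)nc1`, has not yet been measured. It differs from compound 2 in one place: 5-carboxypyridin-2-yl in place of 4-(carboxymethyl)phenyl on an amide-type nitrogen. The acid group thus sits directly on the ring instead of on a one-carbon chain, and a ring nitrogen is added.

Within the data shown here, no pair of measured compounds that differs in one place is available, so this step has no direct precedent. The closest related change, from compound 2 to compound 3, lengthens the chain and brings a large gain; compound 4 goes the other way, shortening it. The expectation is therefore a step of a 1.2-fold higher number from compound 2 to compound 4 (0.09 log units; within the scatter), within the scatter or at most a modest loss. Compound 4 is estimated at 6000 nM, with a range from 1500 nM to 25000 nM.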

Compound 4, half-maximal effective concentration: 10600 nM
Compound 4: the middle estimate sits 1.8-fold (0.25 log units) below what was measured; the measured number falls inside the stated range.
By their numbers in this assay, from the lowest: compound 3; then compounds 2, 1 and 4 (each within the scatter of the next, the first and the last beyond it).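

In this assay, putting 5-carboxypyridin-2-yl in place of 4-(carboxymethyl)phenyl on the amide-type nitrogen gives a 2.2-fold higher number from compound 2 to compound 4 (0.34 log units; beyond the scatter) and so counts as a modest loss. This is the first step shown at this position, and it shows that this swap does not improve on an already weak compound. However, the step combines two changes, moving the acid directly onto the ring and adding a ring nitrogen, and nothing available explains the loss.

The compounds shown leave open which of these two changes accounts for the step. A carbon-only ring bearing the carboxylic acid directly, and a pyridine ring keeping the one-carbon chain or a longer chain to the acid, would each separate the two changes.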